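From cyclobutyl to 2-methoxy-2-methylpropyl

The source may report more compounds than this note shows. Statements on the series, on what has been measured and on what is new or still open speak of the compounds shown alone.

In an ADME assay on Huh-7 cells (Homo sapiens) for cytotoxicity, with a stated time of 72 h (a higher number here means that more compound is tolerated, a lower number that less compound is tolerated), compound 1 (`CC(C)(C)CCn1nc(-c2cccs2)c(O)c(C2=NS(=O)(=O)c3cc(NS(C)(=O)=O)ccc3N2)c1=O`) gives > 1000 nM, which is a limit of the assay and not a number. Compound 2 (`CS(=O)(=O)Nc1ccc2c(c1)S(=O)(=O)N=C(c1c(O)c(-c3cccs3)nn(CC3CCC3)c1=O)N2`) gives > 1000 nM, again only a limit. The record so far is therefore (the limit of > 1000 nM in this assay, at which 2 of the 2 values shown sit). Compound 3 (`COC(C)(C)CCn1nc(-c2cccs2)c(O)c(C2=NS(=O)(=O)c3cc(NS(C)(=O)=O)ccc3N2)c1=O`) carries 2-methoxy-2-methylpropyl in place of cyclobutyl on a saturated chain carbon bound to an aromatic nitrogen. Among the compounds with values here, the one measured change at this place, a step that the two limits leave unreadable from compound 1 to compound 2, offers no size to carry over, so no shift beyond the scatter is expected in this assay. The expected change is an estimated step that the limit leaves unreadable from compound 2 to compound 3, and a further limit is the most likely report. As a number, compound 3 is expected at 2000 nM, with an estimated range of 1000 nM to 10000 nM.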

Compound 3, half-maximal cytotoxic concentration: > 33000 nM
Compound 3: only a limit was reported; the forecaster's own chance of this, stated with the estimate: 90%; middle value at least 16-fold (1.21 log units) away from the limit.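

In this assay, within the data shown here, compound 1, compound 2 and compound 3 are each reported only as a limit, so no step among them can be read. From the compounds shown here alone, whether exchanging these groups on the saturated chain carbon changes the tolerated concentration at all remains open.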